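A few compounds are considered here, and "the series" means these few. Any claim that something is new, unique, unknown or untested is made for them only; others in the source may bear on it.

Measured so far in a functional assay on PC-3 cells (Homo sapiens) for cytotoxicity, read by MTT assay, with a stated time of 48 h; on this read-out lower numbers stand for higher toxicity in this test and higher numbers for lower toxicity in this test:

Compound 1 `O=Cc1c(Nc2ccccc2)oc2ccccc2c1=O` gives 8200 nM.
Compound 2 `O=Cc1c(Nc2ccccc2)oc2ccc(Cl)cc2c1=O` gives 8300 nM.
Compound 3 `CN(c1ccccc1)c1oc2ccccc2c(=O)c1C=O` gives 500 nM.

Compound 3 holds the lowest number of the three. Its nearest neighbour is compound 1: the step is a 16-fold lower number from compound 1 to compound 3 (1.21 log units; beyond the scatter), which comes from methyl in place of hydrogen on a nitrogen on an aromatic ring. Compound 2, with its own value given above, lies a little further off again.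

Compound 4 `CN(c1ccccc1)c1oc2ccc(Cl)cc2c(=O)c1C=O` takes the structure of compound 3 and introduces (chloro in place of hydrogen on an aromatic carbon). The same change has already been seen once on this core, going from compound 1 to compound 2 in this assay: a 1.0-fold higher number from compound 1 to compound 2 (0.01 log units; within the scatter). That step lies within the scatter, so on the evidence in hand the chloro group neither raises nor lowers the number in any meaningful way. Compound 3 is therefore expected to carry its value across nearly unchanged, giving an estimated step of no change at the digits printed from compound 3 to compound 4 (within the scatter). Compound 4 is accordingly estimated at 500 nM in this assay, with a range from 200 nM to 1300 nM.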

Compound 4, concentration lethal to 50% of the cells: 2100 nM
Beside the measured number, compound 4's estimate is 4.2-fold (0.62 log units) below it; the measured number lies above the stated range.
By their numbers in this assay, from the lowest: compound 3; then compound 4; then compounds 1 and 2 (each within the scatter of the next).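

In this assay, the chloro group on the aromatic carbon no longer leaves the number unchanged once the nitrogen carries a methyl, giving a 4.2-fold higher number from compound 3 to compound 4 (0.62 log units; beyond the scatter), so the flat result seen earlier does not hold on both cores: the same change on two cores in this assay, a 1.0-fold higher number (0.01 log units; within the scatter) from compound 1 to compound 2 and a 4.2-fold higher number (0.62 log units; beyond the scatter) from compound 3 to compound 4, 4.1-fold (0.62 log units) apart, beyond the scatter of two such steps. Read from the other side, methyl in place of hydrogen on the nitrogen still lowers the number with the chloro group present, giving a 4.0-fold lower number from compound 2 to compound 4 (0.60 log units; beyond the scatter), but this step is smaller than the one without chloro: the same change on two cores in this assay, a 16-fold lower number (1.21 log units; beyond the scatter) from compound 1 to compound 3 and a 4.0-fold lower number (0.60 log units; beyond the scatter) from compound 2 to compound 4, 4.1-fold (0.62 log units) apart, beyond the scatter of two such steps. The two changes therefore do not add independently in these four compounds, as the size of each step depends on whether the other change is present.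

The compounds shown leave open whether this dependence belongs to chloro itself or would also appear with fluoro or methoxy on the same aromatic carbon, and whether it is tied to this position at all. On these data alone, it is also open whether a longer chain on the nitrogen, such as ethyl or propyl, would behave like methyl, and nothing here tells why the two changes interact.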